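Swapping 3-fluorophenyl for 4-hydroxyphenyl on compound 3

The compounds below may be only part of what the source reports. "The series", "measured", "known", "first", "only" and "open" are said of these compounds alone.

Measured so far in an ADME assay on Raji cells (Homo sapiens) for cytotoxicity, with a stated time of 72 h (on this read-out higher numbers stand for an effect only at larger amounts of compound and lower numbers for an effect already at smaller amounts), with every entry a limit
Compound 1 `Cc1ccc(NC(=O)Nc2cc(C)nc3ccccc23)cc1` gives > 25000 nM as a limit
Compound 2 `Cc1cc(NC(=O)Nc2ccc(F)cc2)c2ccccc2n1` gives > 25000 nM as a limit
Compound 3 `Cc1cc(NC(=O)Nc2cccc(F)c2)c2ccccc2n1` gives > 25000 nM as a limit

Compound 3 reads > 25000 nM in this assay and this is a limit, not a number. It shares that place with the other measured compounds, as shown by the limit of > 25000 nM in this assay, at which 3 of the 3 values shown sit, so no order among them can be read.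

The next molecule is compound 4 `Cc1cc(NC(=O)Nc2ccc(O)cc2)c2ccccc2n1`, which carries 4-hydroxyphenyl in place of 3-fluorophenyl on an amide-type nitrogen. Among the measured compounds shown here, the counted difference is 4-hydroxyphenyl in place of 3-fluorophenyl on an amide-type nitrogen and it adds the only hydroxy group in this small set.

For the measured compounds named here, three measured steps bear on this change: a step that the two limits leave unreadable from compound 1 to compound 2, then a step that the two limits leave unreadable from compound 1 to compound 3 and finally a step that the two limits leave unreadable from compound 2 to compound 3 as the third. None of them has a size that can be read, and none involves a 4-hydroxyphenyl group. They therefore give no reason to expect a step beyond the scatter in either direction, and a further limit is the likeliest outcome.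

The expected change is a number no higher from compound 3 to compound 4 (the limit leaves the size open) and it remains an estimate. For compound 4 the estimated value is 25000 nM with an expected range from 10000 nM to 40000 nM in this assay for now.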

Compound 4, half-maximal effective concentration: > 25000 nM
Compound 4: no number, only a limit; the forecaster's own chance of this, stated with the estimate: 75%; the middle value sits exactly at the limit.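

Compound 4 gives > 25000 nM in this assay, and this is a limit, not a number. No step between compound 4 and compound 1, compound 2 or compound 3 can be read, because all four share one place: the limit of > 25000 nM in this assay, at which 4 of the 4 values shown sit.

The compounds shown leave open how these four rank against each other and at what amount of compound any of them would show an effect.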